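Compound 1 without its carboxy group

A few compounds are considered here, and "the series" means these few. Any claim that something is new, unique, unknown or untested is made for them only; others in the source may bear on it.

Compound 1 (`Cc1ccc(-c2nc3ccccc3s2)cc1NC(=O)c1cc([N+](=O)[O-])c(N2CCC(C(=O)O)CC2)cc1Cl`) has no exact reading in an ADME assay on HepG2 cells (Homo sapiens) for cytotoxicity, with a stated time of 72 h; a higher number here means that more compound is needed for the effect, a lower number that less compound is needed. Compound 1 gives > 25000 nM, which is a limit of the assay and not a number. Compound 2 (`O=C(Nc1nc(-c2ccc(Cl)cc2)cs1)c1cc([N+](=O)[O-])ccc1Cl`) gives > 27000 nM, which is also a limit. Within the data shown here, the series therefore holds no exact value so far, and no measured pair differs in one place. Any expectation for a single change has no direct precedent here.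

Compound 3 (`Cc1ccc(-c2nc3ccccc3s2)cc1NC(=O)c1cc([N+](=O)[O-])c(N2CCCCC2)cc1Cl`) remains unmeasured. Its difference from compound 1 is hydrogen in place of carboxy on a saturated ring carbon, turning 4-carboxypiperidin-1-yl into piperidin-1-yl. The expected step of an at least 1.3-fold lower number from compound 1 to compound 3 (0.14 log units; that floor lies within the scatter) is modest, in the direction of less compound needed for the effect in this assay, and it may not clear the scatter. For compound 3 the estimated value is 18000 nM, with an expected range of 5000 nM to 45000 nM.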

Compound 3, half-maximal effective concentration: > 25000 nM
Compound 3: no number, only a limit; the forecaster's own chance of this, stated with the estimate: 55%; at least 1.3-fold (0.14 log units) between middle value and limit.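

No step from compound 1 to compound 3 can be read in this assay, since both readings are limits of the assay: the limit of > 25000 nM in this assay, at which 2 of the 3 values shown sit.

Whether hydrogen in place of carboxy shifts the half-maximal effective concentration at all stays open, and the compounds shown give no exact value to compare.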